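Octylsulfanyl in place of propylamino: cytotoxicity notes

The compounds below may be only part of what the source reports. "The series", "measured", "known", "first", "only" and "open" are said of these compounds alone.

Measured in an ADME assay on BCBL1 cells (Homo sapiens) for cytotoxicity, with a stated time of 7 days; a lower number here means that less compound is tolerated, a higher number that more compound is tolerated:
- compound 1 `CC(C)CSc1nc(N)nc2c1ncn2/C=C1/CC1(CO)CO`: > 20000 nM (a limit)
- compound 2 `COCCOc1nc(N)nc2c1ncn2/C=C1/CC1(CO)CO`: > 20000 nM (a limit)
- compound 3 `CCCNc1nc(N)nc2c1ncn2/C=C1/CC1(CO)CO`: > 20000 nM (a limit)

For the measured compounds named here, the series so far sits at the limit of > 20000 nM in this assay, at which 3 of the 3 values shown sit. In this assay compound 3 gives > 20000 nM, which is a limit and not a number. The next change leads to compound 4 `CCCCCCCCSc1nc(N)nc2c1ncn2/C=C1/CC1(CO)CO`, with octylsulfanyl in place of propylamino on an aromatic carbon.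

The nearest measured change is a step that the two limits leave unreadable from compound 1 to compound 3, and it joins isobutylsulfanyl and propylamino. The other two, a step that the two limits leave unreadable from compound 1 to compound 2 and a step that the two limits leave unreadable from compound 2 to compound 3, give no size either. Compound 1 also carries a sulfanyl group and gives > 20000 nM, again a limit. Going by the values given here, no measured compound carries a chain as long as octylsulfanyl, so the series offers no step size to carry over. A modest fall in the tolerated concentration is expected as a cautious guess, and another limit is about as likely. The expected change is an at least 1.3-fold lower number from compound 3 to compound 4 (0.12 log units; that floor lies within the scatter). Compound 4 is estimated at 15000 nM, with an expected range from 5000 nM to 30000 nM.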

Compound 4, half-maximal cytotoxic concentration: > 20000 nM
Compound 4: no number, only a limit (the forecaster's own chance of this, stated with the estimate: 55%); at least 1.3-fold (0.12 log units) between middle value and limit.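

In this assay compound 4 gives > 20000 nM, again a limit and not a number. No step among compound 1, compound 2, compound 3 and compound 4 can be read: the limit of > 20000 nM in this assay, at which 4 of the 4 values shown sit.

The compounds shown leave open where the half-maximal cytotoxic concentration of each lies, and whether changing the group on the aromatic carbon shifts it at all.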